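A few compounds are considered here, and "the series" means these few. Any claim that something is new, unique, unknown or untested is made for them only; others in the source may bear on it.

The set opens with compound 1 `N#Cc1cc(-c2nc(C(c3ccc(F)cc3)c3ccc(F)cc3)sc2CC(=O)O)ccc1F`, which in an in vitro assay on HEK385-7 cells for displacement of a labelled ligand from prostaglandin D2 receptor 2 (Homo sapiens) (a higher number here means a weaker inhibitor, a lower number a stronger inhibitor), gives 57 nM. Compound 2 `CCC(c1ccccc1)c1nc(-c2ccc(Cl)cc2)c(CC(=O)O)s1` stands highest of the two numbers that are known, giving 190 nM in this assay; its nearest neighbour, compound 1, sits lower by a gap that lies beyond the usual scatter. Going by the values given here, compound 3 `COc1ccc(OC)c(-c2nc(C(c3ccccc3)c3ccccc3)sc2CC(=O)O)c1` is different: in this assay compound 3 reaches only > 105 nM, which is a limit of the assay and not a number, and it is the one value of the three that sits at the limit of > 105 nM in this assay, at which 1 of the 3 values shown sits.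

Compound 4 `O=C(O)Cc1sc(C(c2ccccc2)c2ccc(Cl)cc2)nc1-c1ccc(Cl)cc1` is not yet measured. It differs from compound 2 in one place: 4-chlorophenyl in place of ethyl on a saturated chain carbon bound to two aromatic carbons. Among the compounds with values here, no measured pair shows this exact exchange, so its size must be inferred. Compound 1, which also bears a six-membered aromatic ring of carbon only on the saturated chain carbon of its core, gives 57 nM, the lowest number known here. On that basis the step is expected to run downward, beyond the scatter, with an estimated change from compound 2 to compound 4 of a 4.2-fold lower number from compound 2 to compound 4 (0.63 log units; beyond the scatter) in this assay. Compound 4 is therefore estimated at 45 nM, in a range from 12 nM to 160 nM.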

Compound 4, half-maximal inhibitory concentration: 45 nM
For compound 4 middle estimate and measured number coincide at the digits printed, and the stated range covers the measured number.
By their numbers in this assay, from the lowest: compounds 4 and 1 (each within the scatter of the next); then compound 2.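

In this assay, going by these compounds alone, the saturated chain carbon bound to two aromatic carbons now has its first single-place exchange, since no earlier pair differed in only one place: 4-chlorophenyl in place of ethyl gives a 4.2-fold lower number from compound 2 to compound 4 (0.63 log units; beyond the scatter). The step shows that the number in this series responds to the group at this carbon, and that a second six-membered aromatic ring of carbon only, carrying chlorine, can stand there in place of a short open chain without any loss in this assay. Nothing measured here accounts for the size or direction of this step.

The compounds shown leave open whether the ring itself or its chlorine carries the step, as the frame of compound 2 offers no direct comparison with a phenyl, a 4-fluorophenyl or a 4-methoxyphenyl at this carbon. They also leave open how a methyl, a longer chain such as propyl, or an amine would behave at the same carbon, and whether the same exchange gives a step of similar size on other substituted versions of the shared core.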